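A few compounds are considered here, and "the series" means these few. Any claim that something is new, unique, unknown or untested is made for them only; others in the source may bear on it.

Three compounds built on one shared core were tested in a functional assay on B16 cells (Mus musculus) for cytotoxicity, read by CCK-8 assay, with a stated time of 24 h; on this read-out lower numbers stand for stronger inhibition and higher numbers for weaker inhibition. Compound 1 `COc1ccccc1Oc1c(N)nc(-c2ccc(F)cc2)nc1Cl` gives 2990 nM. Compound 2 `COc1ccccc1Oc1c(N)nc(-c2cccc(Cl)c2)nc1Cl` gives 17900 nM, and compound 3 `COc1ccccc1Oc1c(N)nc(-c2ccc(F)cc2)nc1OCCO` gives 30100 nM. The change 3-chlorophenyl in place of 4-fluorophenyl on an aromatic carbon brought a 6.0-fold higher number from compound 1 to compound 2 (0.78 log units; beyond the scatter). The two cores differ by 2-hydroxyethoxy in place of chloro on an aromatic carbon, a change that brought a 10-fold higher number from compound 1 to compound 3 (1.00 log units; beyond the scatter). Compound 3 carries the highest number of the three, but its gap to compound 2 lies within the scatter, so no order between those two can be claimed.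

Compound 4 `COc1ccccc1Oc1c(N)nc(-c2cccc(Cl)c2)nc1OCCO` has not yet been measured. It differs from compound 3 by 3-chlorophenyl in place of 4-fluorophenyl on an aromatic carbon. For the measured compounds named here, this is the same kind of change as the one from compound 1 to compound 2, not the same change. The surroundings differ: the place is meta to a chloro group in the first case and meta to a 2-hydroxyethoxy group in the second, and the para group is named only by its count in the first case. Going by the values given here, only one earlier instance exists. Among the compounds with values here, the expected step is a 3.7-fold higher number from compound 3 to compound 4 (0.56 log units; beyond the scatter) in this assay, resting on the single earlier step of a 6.0-fold higher number from compound 1 to compound 2 (0.78 log units; beyond the scatter) and on the high starting number of compound 3 at 30100 nM. Compound 4 is estimated at 110000 nM, expected to fall between 40000 nM and 300000 nM, with a real chance that only a limit is reported.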

Compound 4, half-maximal inhibitory concentration: 5010 nM
For compound 4 the middle estimate is 22-fold (1.34 log units) above the measured one, and the stated range ends above it.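

In this assay, putting 3-chlorophenyl in place of 4-fluorophenyl on the core carrying 2-hydroxyethoxy gave a 6.0-fold lower number from compound 3 to compound 4 (0.78 log units; beyond the scatter), which runs opposite to the earlier step on the core carrying chloro: the same change on two cores in this assay, a 6.0-fold higher number (0.78 log units; beyond the scatter) from compound 1 to compound 2 and a 6.0-fold lower number (0.78 log units; beyond the scatter) from compound 3 to compound 4, 36-fold (1.56 log units) apart, beyond the scatter of two such steps. The exchange of chloro for 2-hydroxyethoxy likewise failed to carry over, giving a 3.6-fold lower number from compound 2 to compound 4 (0.55 log units; beyond the scatter) on the core with 3-chlorophenyl: the same change on two cores in this assay, a 10-fold higher number (1.00 log units; beyond the scatter) from compound 1 to compound 3 and a 3.6-fold lower number (0.55 log units; beyond the scatter) from compound 2 to compound 4, 36-fold (1.56 log units) apart, beyond the scatter of two such steps. These two results are one finding seen from two sides: among these four compounds, neither change keeps its direction from one core to the other, so the outcome of each depends on the group at the other place, but a single set of four compounds does not show why this happens or whether it holds across the series.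

The compounds shown leave open whether the reversal persists with other aryl groups, such as an unsubstituted phenyl. They also leave open what happens with other groups in place of chloro and 2-hydroxyethoxy, such as methoxy, an amine or a longer chain ending in a hydroxyl.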